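A few compounds are considered here, and "the series" means these few. Any claim that something is new, unique, unknown or untested is made for them only; others in the source may bear on it.

Working notes on the quinoline-type series.

The shared core carries two phenyl rings on the pyridine-type ring and a substituent on the benzo side. Compound 1 `O=[N+]([O-])c1ccc2c(-c3ccccc3)cc(-c3ccccc3)nc2c1` has a nitro group there; in an ADME assay on CCD 19Lu cells (Homo sapiens) for antiproliferative activity, read by MTT assay, with a stated time of 24 h (a lower number here means a stronger inhibitor, a higher number a weaker inhibitor), compound 1 gives "not determined" (no result reported). For the measured compounds named here, compound 2 `COc1cc(-c2cc(-c3ccccc3)c3cc(Br)ccc3n2)cc(OC)c1OC` carries bromine on the benzo side and a trimethoxyphenyl ring; in this assay compound 2 gives 105000 nM, the only number so far, and a weak one. Compound 3 `Fc1ccc(-c2cc(-c3ccccc3)c3cc(Br)ccc3n2)cc1` keeps the bromine and carries a 4-fluorophenyl ring; in this assay compound 3 gives "not determined" (no result reported), so compound 3 stands without a number, as does compound 1, and its place relative to compound 2 cannot be read.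

Compound 4 `Oc1ccc(-c2cc(-c3ccccc3)c3cc(Br)ccc3n2)cc1` differs from compound 3 by hydroxy in place of fluoro on an aromatic carbon. Going by the values given here, no step between measured compounds is available to anchor this change, so the expectation rests on compound 2 alone. Given the weak result of compound 2 at 105000 nM, a value of similar order is expected for compound 4, with no confident direction; the change may land either side of the scatter. Compound 4 is estimated in this assay at 60000 nM, within a range of 10000 nM to 250000 nM, with a real chance that only a limit is reported.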

Compound 4, half-maximal inhibitory concentration: 104000 nM
Compound 4: middle estimate off by 1.7-fold (0.24 log units), on the low side; measured number inside the range.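

No step can be read for compound 4 against compound 3: in this assay compound 3 gives "not determined" (no result reported) and offers no number to compare. The compounds shown leave open how 4-fluorophenyl to 4-hydroxyphenyl affects the result in this assay on this shared core. No separate data bear on this result.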